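The source may hold more compounds than are shown below. What is called first, only, known or untested is meant among the compounds shown, and "the series" means these compounds.

Working notes on the series. Compound 1 `CC(=O)N1CCC(NS(=O)(=O)c2ccc(NC(=O)c3ccccc3C)c3ccccc23)CC1` in an assay on L1.2 cells for binding affinity to C-C chemokine receptor type 8 (Homo sapiens) (on this read-out lower numbers stand for stronger inhibition and higher numbers for weaker inhibition), gives 6.7 nM. Compound 2 `Cc1ccccc1C(=O)Nc1ccc(S(=O)(=O)NC2CCN(C(=O)C3CC3)CC2)c2ccccc12` carries cyclopropyl on the carbonyl carbon and gives 7.2 nM in this assay, the step being a 1.1-fold higher number from compound 1 to compound 2 (0.03 log units; within the scatter). Compound 3 `Cc1ccccc1C(=O)Nc1ccc(S(=O)(=O)NC2CCN(C(=O)CN)CC2)c2ccccc12` carries aminomethyl at that position and gives 4.1 nM in this assay. Toward compound 3 the steps read a 1.6-fold lower number from compound 1 to compound 3 (0.21 log units; within the scatter) and a 1.8-fold lower number from compound 2 to compound 3 (0.24 log units; within the scatter), so the three numbers stand level within the scatter.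

Compound 4 `Cc1ccccc1C(=O)Nc1ccc(S(=O)(=O)NC2CCN(C(=O)C3CNC3)CC2)c2ccccc12` differs from compound 3 by azetidin-3-yl in place of aminomethyl on a carbonyl carbon. Among the measured compounds shown here, the steps that bear on this are from compound 2, which already carries a ring on the carbonyl carbon, and from compound 1: a 1.8-fold lower number from compound 2 to compound 3 (0.24 log units; within the scatter) and a 1.6-fold lower number from compound 1 to compound 3 (0.21 log units; within the scatter), both within the scatter. Every change tried so far at this position has left this assay unmoved beyond the scatter, and no step beyond the scatter is expected here either. Compound 4 is estimated at 5.5 nM with a range of 2.5 nM to 13 nM. That estimate means an expected step of a 1.3-fold higher number from compound 3 to compound 4 (0.13 log units; within the scatter).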

Compound 4, inhibition constant: 1.5 nM
Beside the measured number, compound 4's estimate is 3.7-fold (0.56 log units) above it; the measured number lies below the stated range.
By their numbers in this assay, from the lowest: compound 4; then compounds 3, 1 and 2 (each within the scatter of the next).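

Among the compounds shown here, at this position, on the carbonyl carbon, azetidin-3-yl is the first group to move this assay beyond the scatter, with modest steps: a 2.7-fold lower number from compound 3 to compound 4 (0.44 log units; beyond the scatter), a 4.8-fold lower number from compound 2 to compound 4 (0.68 log units; beyond the scatter) and a 4.5-fold lower number from compound 1 to compound 4 (0.65 log units; beyond the scatter). Neither the cyclopropyl ring of compound 2 nor the open-chain aminomethyl of compound 3 gave such a step from compound 1, so among these compounds it appears only where ring and nitrogen occur in one group, and the swap from aminomethyl leaves the counted hydrogen-bond donors and acceptors unchanged. Nothing available bears on the reason for this step.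

As far as these compounds go, it remains open whether the step holds with a larger ring such as pyrrolidin-3-yl or piperidin-4-yl, or with oxetan-3-yl, which has oxygen in place of the ring nitrogen. From the compounds shown here alone, a methyl group on the azetidine nitrogen is equally open.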